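A few compounds are considered here, and "the series" means these few. Any claim that something is new, unique, unknown or untested is made for them only; others in the source may bear on it.

Compound 1 `COc1cc(-c2ccnc3cc(-c4cn(CO)c5ccccc45)nn23)cc(OC)c1OC`: 93 nM
Compound 2 `COc1cc(-c2ccnc3cc(-c4ccc(C(F)(F)F)cc4)nn23)cc(OC)c1OC`: 1770 nM

For the measured compounds named here, in a functional assay on B16-F0 cells (Mus musculus) for inhibition, read by CCK-8 assay, with a stated time of 48 h (a higher number here means a weaker inhibitor, a lower number a stronger inhibitor), compound 1 gives 93 nM, the lower of the two numbers measured so far, while compound 2 gives 1770 nM, a higher number that sits well beyond the usual scatter. Compound 3 `COc1cc(-c2ccnc3cc(-c4cn(C)c5ccccc45)nn23)cc(OC)c1OC` has not yet been measured. It differs from compound 1 in one place: hydrogen in place of hydroxy on a saturated chain carbon bound to an aromatic nitrogen. Going by the values given here, no measured pair shows this change, so its size is not known from the data. The change is small, a hydroxy swapped for a hydrogen, and the step of a 1.1-fold higher number from compound 1 to compound 3 (0.03 log units; within the scatter) is expected to stay within the scatter, with no direction favoured. Compound 3 is therefore estimated at 100 nM, within a range from 40 nM to 300 nM.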

Compound 3, half-maximal inhibitory concentration: 185 nM
For compound 3 the middle estimate is 1.9-fold (0.27 log units) below the measured one; low and high end bracket the measured number.
By their numbers in this assay, from the lowest: compounds 1 and 3 (each within the scatter of the next); then compound 2.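

Going from hydroxymethyl to methyl on a saturated chain carbon bound to an aromatic nitrogen gives a 2.0-fold higher number from compound 1 to compound 3 (0.30 log units; within the scatter) in this assay, so the hydroxy is not required for a number in this range. Replacing 4-(trifluoromethyl)phenyl with 1-methyl-1H-indol-3-yl on an aromatic carbon gives a 9.6-fold lower number from compound 2 to compound 3 (0.98 log units; beyond the scatter), showing that the gap to compound 2 largely remains without the hydroxy. No available evidence explains either step. From the compounds shown here alone, it remains open how an amine, a carboxylic acid or a longer chain such as ethyl in place of the methyl of compound 3 would read.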